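Trimming the amine substituent of compound 2

The source may report more compounds than this note shows. Statements on the series, on what has been measured and on what is new or still open speak of the compounds shown alone.

In a functional assay on the whole organism with Mus musculus as the target (on this read-out higher numbers stand for an effect only at larger amounts of compound and lower numbers for an effect already at smaller amounts), compound 1 `CNC(=O)[C@H](C)NCc1ccc(OCc2ccccc2)cc1` gives 8.4 mg/kg, while compound 2 `CNC(=O)[C@@H](NCc1ccc(OCc2ccccc2)cc1)C(C)C` gives 55.4 mg/kg, the higher of the two numbers. Compound 3 `CC[C@H](NCc1ccc(OCc2ccccc2)cc1)C(N)=O` carries 1-carbamoylpropyl in place of 2-methyl-1-(methylcarbamoyl)propyl on an amine nitrogen. Among the compounds with values here, the one measured step that bears on this is a 6.6-fold higher number from compound 1 to compound 2 (0.82 log units; beyond the scatter), with isopropyl in place of methyl. Within the data shown here, no measured step isolates methylcarbamoyl changing to carbamoyl, so the guess is loose. The expected step is towards a lower number, a 2.8-fold lower number from compound 2 to compound 3 (0.44 log units; beyond the scatter), smaller than that measured one. For compound 3 the estimated value is 20 mg/kg, within a range of 7 mg/kg to 55 mg/kg.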

Compound 3, dose for half-maximal effect: 119 mg/kg
For compound 3 the middle estimate is 6.0-fold (0.77 log units) below the measured one; measured number outside the range, above it.
By their numbers in this assay, from the lowest: compound 1; then compound 2; then compound 3.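

With a 2.1-fold higher number from compound 2 to compound 3 (0.33 log units; beyond the scatter) in this assay and a 14-fold higher number from compound 1 to compound 3 (1.15 log units; beyond the scatter) alongside it, trimming the group on the amine nitrogen does not lower the number here. The earlier rise with isopropyl therefore does not make smaller better at this position, as compound 3 carries a smaller group than compound 2 yet has the higher number. Nothing measured explains this. As far as these compounds go, compound 3 differs from compound 2 in both the chain and the amide, so their separate shares stay unknown. A 1-(methylcarbamoyl)propyl group or a carboxylic acid in place of the carbamoyl would help separate them.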